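The source may report more compounds than this note shows. Statements on the series, on what has been measured and on what is new or still open speak of the compounds shown alone.

Three compounds share one core and differ only in the chain hanging from the oxygen on its aromatic ring. Compound 1 `CCOC(=O)COc1ccc2c(=O)c(-c3ccc(O)cc3)coc2c1` carries an ethoxycarbonyl there; in an assay (Cricetulus griseus) for inhibition of aldehyde dehydrogenase, mitochondrial (Homo sapiens) (a lower number here means a stronger inhibitor, a higher number a weaker inhibitor), compound 1 gives 130 nM. Compound 2 `O=C(O)CCCCCCOc1ccc2c(=O)c(-c3ccc(O)cc3)coc2c1` carries a 5-carboxypentyl instead and gives 50 nM, while compound 3 `O=C(O)CCCCCCCOc1ccc2c(=O)c(-c3ccc(O)cc3)coc2c1` carries a 6-carboxyhexyl and gives 40 nM. Compound 3 thus holds the lowest number of the three, though it sits within the scatter of compound 2 and is set apart only from compound 1 by a 3.3-fold lower number from compound 1 to compound 3 (0.51 log units; beyond the scatter).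

Compound 4 `O=C(O)CCCCOc1ccc2c(=O)c(-c3ccc(O)cc3)coc2c1` is the next step: carboxy in place of 3-carboxypropyl on a saturated chain carbon, four bonds along the chain from an oxygen on an aromatic ring. The chain is shortened but keeps its carboxy end. Among the measured compounds shown here, two measured steps bear on this. Lengthening the acid chain by one carbon, a 1.3-fold lower number from compound 2 to compound 3 (0.10 log units; within the scatter), changed little. Replacing the short ethoxycarbonyl with the longer acid chains, a 2.6-fold lower number from compound 1 to compound 2 (0.41 log units; beyond the scatter) and a 3.3-fold lower number from compound 1 to compound 3 (0.51 log units; beyond the scatter), brought modest gains. Cutting three carbons away is therefore expected to cost some of that gain, so a modest rise, a 2.0-fold higher number from compound 3 to compound 4 (0.30 log units; within the scatter), is expected. Compound 4 is estimated at 80 nM, between 35 nM and 200 nM.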

Compound 4, half-maximal inhibitory concentration: 100 nM
The estimate for compound 4 lay 1.3-fold (0.10 log units) below the measured number, and the stated range covers the measured number.
By their numbers in this assay, from the lowest: compounds 3, 2, 4 and 1 (each within the scatter of the next, the first and the last beyond it).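

Shortening the chain has a real cost only over the full cut: a 2.5-fold higher number from compound 3 to compound 4 (0.40 log units; beyond the scatter) is beyond the scatter, whereas a 2.0-fold higher number from compound 2 to compound 4 (0.30 log units; within the scatter) stays within it, so the loss appears gradually rather than at one clear chain length. A carboxylic acid end on a short chain is also not enough to stand apart from the ester, since a 1.3-fold lower number from compound 1 to compound 4 (0.11 log units; within the scatter) lies within the scatter, and only the 5-carboxypentyl and 6-carboxyhexyl chains are clearly better than ethoxycarbonyl. Nothing measured here explains why chain length matters at this position.

From the compounds shown here alone, whether a chain longer than 6-carboxyhexyl would lower the number further or bring it back up remains open. Also open, going by these compounds, is whether the acid end matters on a long chain, which an ethyl ester or an amine at the end of the 6-carboxyhexyl chain could test.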